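The source may report more compounds than this note shows. Statements on the series, on what has been measured and on what is new or still open speak of the compounds shown alone.

Compound 1 `O=[N+]([O-])c1ccc(-c2cc(-c3ccc(F)cc3)n[nH]2)cc1` gives 18100 nM in a functional assay on SW-620 cells (Homo sapiens) for inhibition, read by MTT assay, with a stated time of 48 h; on this read-out lower numbers stand for stronger inhibition of growth and higher numbers for weaker inhibition of growth.
Compound 2 `COc1ccc(-c2cc(-c3ccccc3)n[nH]2)cc1` gives 27200 nM in this assay.
Compound 3 `COc1ccc(-c2cc(-c3ccccc3-c3ccccc3)n[nH]2)cc1` gives 890 nM in this assay.

In this assay compound 3 stands lowest of the three, with compound 1 nearest to it and compound 2 furthest away. Going by the values given here, the only step that changes one place, a 31-fold lower number from compound 2 to compound 3 (1.49 log units; beyond the scatter), is large and separates compound 3 from compound 2. Compound 4 `O=[N+]([O-])c1ccc(-c2cc(-c3ccccc3-c3ccccc3)n[nH]2)cc1` differs from compound 3 by nitro in place of methoxy on an aromatic carbon. Among the compounds with values here, no measured step changes this group alone. Compound 1 and compound 2 differ in this group and in another place as well, and their values in this assay lie close to one another, so they give no sign that nitro in place of methoxy moves the number far in either direction. The writer therefore expects no step beyond the scatter, a 1.1-fold higher number from compound 3 to compound 4 (0.05 log units; within the scatter). For compound 4 the estimate is 1000 nM, with a range from 300 nM to 3500 nM.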

Compound 4, concentration for 50% growth inhibition: 12200 nM
Compound 4: the middle estimate sits 12-fold (1.09 log units) below what was measured; measured number above the stated range.
By their numbers in this assay, from the lowest: compound 3; then compounds 4, 1 and 2 (each within the scatter of the next, the first and the last beyond it).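

Here the change from methoxy to nitro can be read alone for the first time, and in this assay it is far from neutral: a 14-fold higher number from compound 3 to compound 4 (1.14 log units; beyond the scatter), so the group on this aromatic carbon, para to a large group, strongly affects the read-out when the phenyl of compound 3 is present. Thus the low number of compound 3 depends on methoxy at this position as well as on that phenyl, whose own step, a 31-fold lower number from compound 2 to compound 3 (1.49 log units; beyond the scatter), was read only with methoxy in place. No available evidence bears on the cause of the nitro step.

Going by these compounds, whether nitro in place of methoxy has a step of similar size without that phenyl remains open. So does how an amine, a hydroxyl or a carboxylic acid at this position would compare with methoxy and nitro.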